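The source may report more compounds than this note shows. Statements on the series, on what has been measured and on what is new or still open speak of the compounds shown alone.

Measured so far in an ADME assay on L929 cells (Mus musculus) for cytotoxicity, read by resazurin assay, with a stated time of 72 h; on this read-out lower numbers stand for stronger inhibition and higher numbers for weaker inhibition:
compound 1 `O=C(/C=C/c1ccc2c(c1)B(O)OC2)c1ccc(I)cc1`, a limit only: > 10 ug/mL
compound 2 `COc1ccccc1C(=O)/C=C/c1ccc2c(c1)B(O)OC2`: 6.35 ug/mL
compound 3 `Nc1cccc(C(=O)/C=C/c2ccc3c(c2)B(O)OC3)c1`: 10 ug/mL

Compound 3 holds the highest of the two numbers read in this assay; the value of compound 2 lies within the scatter of it, so the two cannot be ordered. The entry for compound 1 is a limit, not a number (the limit of > 10 ug/mL in this assay, at which 1 of the 3 values shown sits).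

Compound 4 `O=C(/C=C/c1ccc2c(c1)B(O)OC2)c1ccccc1F` differs from compound 3 in one place: 2-fluorophenyl in place of 3-aminophenyl on a carbonyl carbon. Within the data shown here, the one measured step at the same place, an aryl change on the carbonyl carbon, is a number no higher from compound 1 to compound 3 (the limit leaves the size open), whose size cannot be read because compound 1 sits at the limit (the limit of > 10 ug/mL in this assay, at which 1 of the 3 values shown sits). Among the measured compounds shown here, the series therefore shows no step of known size for swapping the aryl group here, and no direction can be drawn from it.

The expected step is accordingly small, a 1.3-fold lower number from compound 3 to compound 4 (0.10 log units; within the scatter), with the 2-fluorophenyl in place of the 3-aminophenyl estimated to leave compound 4 near compound 3. Compound 4 is estimated at 8 ug/mL, in the range 4 ug/mL to 16 ug/mL, with a fair chance that only a limit is reported.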

Compound 4, half-maximal inhibitory concentration: > 10 ug/mL
Compound 4 gave a limit, no number (the forecaster's own chance of this, stated with the estimate: 40%); middle value at least 1.2-fold (0.09 log units) away from the limit.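

In this assay compound 4 is a limit, not a number, and so is compound 1: with 2-fluorophenyl on the carbonyl carbon, as with 4-iodophenyl there, the reading ends at the limit. Fluoro in place of methoxy on an aromatic carbon gives an at least 1.5-fold higher number from compound 2 to compound 4 (0.19 log units; that floor lies within the scatter) and so supplies a floor for this change, not a size. 2-Fluorophenyl in place of 3-aminophenyl on the carbonyl carbon gives a number no lower from compound 3 to compound 4 (the limit leaves the size open) and so supplies a direction, not a size. The other steps to compound 4 cannot be read, because they end at a limit: the limit of > 10 ug/mL in this assay, at which 2 of the 4 values shown sit.

On these data alone, how far compound 1 and compound 4 lie past the limit stays open, and so does any ranking of the aryl groups that reach it.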